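Compound 3: replacing 2-bromophenyl on the shared core

This account rests on a few compounds, and the source may have more. Where it says the series, first, only, none or still open, it means among the compounds named here.

In a functional assay on T84 cells (Homo sapiens) for antiproliferative activity, read by MTT assay, with a stated time of 72 h (a lower number here means a stronger inhibitor, a higher number a weaker inhibitor), compound 1 `COc1cc(/C=C2\CCC/C(=C\c3ccccc3Br)C2=O)cc(OC)c1OC` gives 4200 nM and compound 2 `COc1cc(/C=C2\CCC/C(=C\c3cccc(O)c3)C2=O)cc(OC)c1OC` gives 6500 nM so the two stand level within the scatter. Compound 3 `COc1cc(/C=C2\CCC/C(=C\c3ccc(O)c(Cl)c3)C2=O)cc(OC)c1OC` has no measured value yet. It carries 3-chloro-4-hydroxyphenyl in place of 2-bromophenyl on a double-bonded chain carbon bound to a double-bonded ring carbon.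

Within the data shown here, only one measured step bears on this change, at the same place: a 1.5-fold higher number from compound 1 to compound 2 (0.19 log units; within the scatter) with 3-hydroxyphenyl entering in place of 2-bromophenyl. Among the measured compounds shown here, no measured compound carries 3-chloro-4-hydroxyphenyl, so this guide is thin. On that single step, no change beyond the scatter is expected in this assay and the estimated step is small, with no firm direction (a 1.2-fold higher number from compound 1 to compound 3 (0.08 log units; within the scatter)). Compound 3 is expected near 5000 nM with an estimated range of 2000 nM to 12000 nM for now.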

Compound 3, half-maximal inhibitory concentration: 1800 nM
Beside the measured number, compound 3's estimate is 2.8-fold (0.44 log units) above it; the whole stated range lies above it.
By their numbers in this assay, from the lowest: compound 3; then compounds 1 and 2 (each within the scatter of the next).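

In this assay, this position now gives a change beyond the scatter: a 2.3-fold lower number from compound 1 to compound 3 (0.37 log units; beyond the scatter), whereas a 1.5-fold higher number from compound 1 to compound 2 (0.19 log units; within the scatter). The step of a 3.6-fold lower number from compound 2 to compound 3 (0.56 log units; beyond the scatter) shows that a hydroxyl on this phenyl ring does not alone set the number, with compound 2 and compound 3 both carrying one but standing apart. No measurement offered here accounts for these steps.

The step from 3-hydroxyphenyl to 3-chloro-4-hydroxyphenyl brings in the chlorine and alters the hydroxyl placement together, and the compounds shown do not separate the two. Also open, going by these compounds, is how 4-hydroxyphenyl without chlorine, 3-chlorophenyl, or a phenyl ring bearing an amine or a carboxylic acid would read at this position on the shared core.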